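The source may report more compounds than this note shows. Statements on the series, on what has been measured and on what is new or still open speak of the compounds shown alone.

The measured compounds:
compound 1, `COc1ccc(S(=O)(=O)N(Cc2ccc(Cl)c([N+](=O)[O-])c2)[C@H](C)C(=O)NO)cc1`, 30 nM;
compound 2, `COc1ccc(S(=O)(=O)N(Cc2cc(C)on2)[C@H](C)C(=O)NO)cc1`, 230 nM;
compound 3, `COc1ccc(S(=O)(=O)N(Cc2sc3scc(C)c3c2C)[C@H](C)C(=O)NO)cc1`, 60 nM.

All three were tested in an assay on isolated protein for inhibition of bone morphogenetic protein 1 (Homo sapiens); on this read-out lower numbers stand for stronger inhibition and higher numbers for weaker inhibition. Compound 1 gives 30 nM, compound 3 gives 60 nM and compound 2 gives 230 nM. Compound 2 stands highest of the three numbers: its nearest neighbour is compound 3, a gap beyond the scatter, and its furthest is compound 1, a larger gap, also beyond the scatter. Compound 2 is therefore the weakest inhibitor of the three in this assay.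

Compound 4, `COc1ccc(S(=O)(=O)N(Cc2cccc(Br)c2)[C@H](C)C(=O)NO)cc1`, has not yet been measured. It differs from compound 2 in one place: 3-bromophenyl in place of 5-methyl-1,2-oxazol-3-yl on a saturated chain carbon bound to a sulfonamide nitrogen. For the measured compounds named here, no measured pair shows this exact change, so any expectation rests on where compound 2 stands against the other two. Compound 1 gives 30 nM and compound 3 gives 60 nM, both well below compound 2, and on that basis the step from compound 2 to compound 4 is expected to be a 4.6-fold lower number from compound 2 to compound 4 (0.66 log units; beyond the scatter), toward a lower number and beyond the scatter. Compound 4 is estimated at 50 nM, with a range from 15 nM to 160 nM.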

Compound 4, half-maximal inhibitory concentration: 93 nM
For compound 4 the middle estimate is 1.9-fold (0.27 log units) below the measured one, within the range that was stated.
By their numbers in this assay, from the lowest: compounds 1, 3 and 4 (each within the scatter of the next, the first and the last beyond it); then compound 2.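

In this assay, the exchange of 5-methyl-1,2-oxazol-3-yl for 3-bromophenyl on a saturated chain carbon bound to a sulfonamide nitrogen gives a 2.5-fold lower number from compound 2 to compound 4 (0.39 log units; beyond the scatter), a modest step that nonetheless lies beyond the scatter. For the compounds shown here, it is the first direct reading of a single change at this position, and it shows that, for this pair, inhibition does not depend on keeping a five-membered aromatic ring with hetero atoms or on hydrogen-bond acceptors in this group, since a six-membered aromatic ring of carbon only, carrying bromine, gives the lower number. Nothing available here accounts for the size or direction of this step.

Going by these compounds, it remains open whether the step belongs to the bromine or to the carbon-only ring itself, which a plain benzyl group would separate, and whether a saturated cyclohexylmethyl group or a longer chain ending in an amine would also be accepted at this place. Also open, on these data alone, is whether the same exchange would give a step of similar size if a carboxylic acid took the place of the hydroxamic acid.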